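This account rests on a few compounds, and the source may have more. Where it says the series, first, only, none or still open, it means among the compounds named here.

Measured so far:
compound 1 `CCCCC(O)CC(=O)O[C@H](CC=C(C)C)C1=CC(=O)c2c(O)ccc(O)c2C1=O` gives 45300 nM
compound 2 `CCCC(C)(O)CC(=O)O[C@H](CC=C(C)C)C1=CC(=O)c2c(O)ccc(O)c2C1=O` gives 75000 nM

Both values come from a functional assay on DU-145 cells (Homo sapiens) for cytotoxicity, read by MTT assay; on this read-out lower numbers stand for stronger inhibition and higher numbers for weaker inhibition. Compound 2 holds the higher of the two numbers, but the step between them, a 1.7-fold higher number from compound 1 to compound 2 (0.22 log units; within the scatter), lies within the scatter, so neither compound can be called the stronger one. Compound 3 `CCCCC(CC(=O)O[C@H](CC=C(C)C)C1=CC(=O)c2c(O)ccc(O)c2C1=O)OC(C)=O` is not yet measured. It differs from compound 2 by 1-acetoxypentyl in place of 1-hydroxy-1-methylbutyl on a saturated chain carbon bound to a carbonyl carbon. Among the measured compounds shown here, only one measured step exists, and it concerns a different change on the same saturated chain carbon bound to a carbonyl carbon: a 1.7-fold higher number from compound 1 to compound 2 (0.22 log units; within the scatter), within the scatter. For the measured compounds named here, no measured step covers the loss of the hydroxyl group or the entry of the acetoxy group, and none covers the longer chain. Going by the values given here, the series so far shows no step beyond the scatter in either direction, so for this assay a step of no more than the scatter is expected. Compound 3 is therefore estimated at 55000 nM, with a range from 20000 nM to 150000 nM. For compound 3 the expected step is a 1.4-fold lower number from compound 2 to compound 3 (0.13 log units; within the scatter), which would leave it within the scatter of compound 2.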

Compound 3, half-maximal inhibitory concentration: 67700 nM
Compound 3: middle estimate off by 1.2-fold (0.09 log units), on the low side; the range from low to high includes it.
By their numbers in this assay, from the lowest: compounds 1, 3 and 2 (each within the scatter of the next).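

Working notes on the acetate: in this assay, the only direct reading of the acetyl cap on the oxygen of the side chain is a 1.5-fold higher number from compound 1 to compound 3 (0.17 log units; within the scatter), so at this position acetyl in place of hydrogen on an oxygen on a saturated carbon gives no readable difference from the free hydroxyl of compound 1. The wider exchange of 1-hydroxy-1-methylbutyl for 1-acetoxypentyl on a saturated chain carbon bound to a carbonyl carbon, which adds heavy atoms and removes the hydroxyl, reads as a 1.1-fold lower number from compound 2 to compound 3 (0.04 log units; within the scatter), so all three compounds now stand within the scatter of one another and none can be ranked. No measurement is at hand that would account for this flat result.

On these data alone, whether any group at this position can move the number beyond the scatter remains open, for example an amine or a carboxylic acid in place of the hydroxyl or acetoxy group, or a longer chain than the pentyl one. Also open, as far as these compounds go, is whether this flat reading holds in cell lines other than the one used here, or with any change on the shared core.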